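The source may report more compounds than this note shows. Statements on the series, on what has been measured and on what is new or still open speak of the compounds shown alone.

Measured in a functional assay on COLO 205 cells (Homo sapiens) for inhibition, read by sulforhodamine B assay; a lower number here means a stronger inhibitor of growth, a higher number a weaker inhibitor of growth:
- Compound 1 `Oc1cccc2[nH]c(-c3ccc(-c4ccc(-c5ccccc5)cc4)cc3)nc12`: 1210 nM
- Compound 2 `Oc1cccc2[nH]c(-c3ccc(-c4ccc(-c5ccc(F)cc5)cc4)cc3)nc12`: 1220 nM
- Compound 3 `Oc1ccc(-c2ccc(-c3ccc(-c4nc5c(O)cccc5[nH]4)cc3)cc2)cc1`: 2600 nM

Compound 3 has the highest number of the three, making it the weakest inhibitor of growth here. Compound 4 `Oc1cccc2[nH]c(-c3ccc(-c4ccc(-c5cccc(Cl)c5)cc4)cc3)nc12` brings one change: 3-chlorophenyl in place of 4-hydroxyphenyl on an aromatic carbon. Two measured steps remove the hydroxy group in reverse: a 2.1-fold higher number from compound 1 to compound 3 (0.33 log units; beyond the scatter) and a 2.1-fold higher number from compound 2 to compound 3 (0.33 log units; beyond the scatter). Both are modest. Fluoro made no difference beyond the scatter, with a 1.0-fold higher number from compound 1 to compound 2 (0.00 log units; within the scatter). Going by the values given here, no measured compound carries chlorine, so this is an uncertain comparison. With the hydroxy gone, a modest fall back towards compound 1 and compound 2 seems likely, and the expected step is a 2.2-fold lower number from compound 3 to compound 4 (0.34 log units; beyond the scatter). The estimate for compound 4 is 1200 nM, with an expected range of 550 nM to 2600 nM.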

Compound 4, concentration for 50% growth inhibition: 8600 nM
Compound 4: middle estimate off by 7.2-fold (0.86 log units), on the low side, and the stated range ends below it.
By their numbers in this assay, from the lowest: compounds 1 and 2 (each within the scatter of the next); then compound 3; then compound 4.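

Chloro in place of hydrogen gives a 7.1-fold higher number from compound 1 to compound 4 (0.85 log units; beyond the scatter) and so shows that this ring can tolerate a change far less quietly than the fluoro compound suggested. The step of a 7.0-fold higher number from compound 2 to compound 4 (0.85 log units; beyond the scatter) is of the same size, while a 3.3-fold higher number from compound 3 to compound 4 (0.52 log units; beyond the scatter) shows that removing the hydroxy group need not bring the number back down. No evidence here accounts for this rise.

Compound 4 differs from compound 2 in both its halogen and that halogen's place, so the two remain unseparated. On these data alone, how a methyl group or an amine would behave in the chlorine's place also remains open.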